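Swapping Nitro for Methylsulfonyl on a Weak Phosphatase Inhibitor

A few compounds are considered here, and "the series" means these few. Any claim that something is new, unique, unknown or untested is made for them only; others in the source may bear on it.

Two related sulfonamides have been tested in an assay on isolated protein for inhibition of dual specificity protein phosphatase 3 (Homo sapiens); a higher number here means a weaker inhibitor, a lower number a stronger inhibitor. Compound 1 `Cc1sc(NS(=O)(=O)/C=C/c2ccccc2Cl)nc1-c1ccc(Cl)cc1` reaches only the limit of the assay, > 100000 nM, which is not a number. Going by the values given here, compound 2 `CCc1sc(NS(=O)(=O)/C=C/c2ccc([N+](=O)[O-])cc2)nc1-c1ccccc1` gives 50000 nM in this assay, the single real number so far. The other result, that of compound 1, is the limit (the limit of > 100000 nM in this assay, at which 1 of the 2 values shown sits). Compound 3 `CCc1sc(NS(=O)(=O)/C=C/c2ccc(S(C)(=O)=O)cc2)nc1-c1ccccc1` differs from compound 2 by methylsulfonyl in place of nitro on an aromatic carbon. Without any measured step of this kind, the change is expected to stay within the usual scatter, a 1.2-fold higher number from compound 2 to compound 3 (0.08 log units; within the scatter). Compound 3 is therefore estimated at 60000 nM, between 20000 nM and 200000 nM.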

Compound 3, half-maximal inhibitory concentration: > 100000 nM
Compound 3: only a limit was reported (the forecaster's own chance of this, stated with the estimate: 40%); at least 1.6-fold (0.22 log units) between middle value and limit.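

In this assay compound 3 reaches only a limit of the assay, > 100000 nM, which is not a number. Going by these compounds, this first measured change at this place on the aromatic ring reads as an at least 2.0-fold higher number from compound 2 to compound 3 (0.30 log units; that floor lies within the scatter), so methylsulfonyl in place of nitro brings no gain here, and the true size of the step stays unknown. Results at the limit now make up most of this small set: the limit of > 100000 nM in this assay, at which 2 of the 3 values shown sit.

On these data alone, whether an amine or a carboxylic acid at this place would improve on compound 2, at 50000 nM, stays open. So does how far beyond its limit compound 3 really lies.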